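The source may report more compounds than this note shows. Statements on the series, on what has been measured and on what is new or still open speak of the compounds shown alone.

Measured in a functional assay on K562 cells (Homo sapiens) for antiproliferative activity, read by CCK-8 assay, with a stated time of 72 h; a lower number here means a stronger inhibitor of growth, a higher number a weaker inhibitor of growth:
- compound 1 `CCC1C(=O)N(C)c2cnc(-n3ccc4cc(C(=O)NC(C)C)ccc43)nc2N1c1ccn(C)n1`: 8910 nM
- compound 2 `CC[C@@H]1C(=O)N(C)c2cnc(Nc3ccc(S(=O)(=O)NC)cc3)nc2N1C1CCCC1`: 222 nM

Compound 1, at 8910 nM, holds the higher of the two numbers and is therefore the weaker inhibitor of growth. Compound 2, at 222 nM, lies lower by a gap beyond the scatter. These two compounds differ in more than one place, so their gap does not give the size of any single change.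

Compound 3 `CCC1C(=O)N(C)c2cnc(-n3ccc4cc(F)ccc43)nc2N1c1ccn(C)n1` keeps the core of compound 1 and differs in one place: fluoro in place of isopropylcarbamoyl on an aromatic carbon.

For the measured compounds named here, no measured pair shows what such a replacement does in this assay, so neither direction can be favoured with confidence. The starting point is therefore compound 1 at 8910 nM, and no step beyond the scatter is expected. The expected move is a 1.1-fold higher number from compound 1 to compound 3 (0.05 log units; within the scatter), an estimate with wide uncertainty. For compound 3 the estimated value is 10000 nM, with an expected range from 3000 nM to 30000 nM.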

Compound 3, concentration for 50% growth inhibition: 6070 nM
Compound 3: middle estimate off by 1.6-fold (0.22 log units), on the high side; the range from low to high includes it.
By their numbers in this assay, from the lowest: compound 2; then compounds 3 and 1 (each within the scatter of the next).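

On an aromatic carbon of a six-membered aromatic ring of carbon only, part of a fused system of two rings, replacing isopropylcarbamoyl with fluoro gives in this assay a 1.5-fold lower number from compound 1 to compound 3 (0.17 log units; within the scatter) and so leaves the number unchanged within the scatter. For the compounds shown here, this is the first single change read, and it shows that, on the core of compound 1, removing a group of six heavy atoms with its hydrogen-bond donor and acceptor and putting a single fluorine in its place produces no measurable step in growth inhibition. No measured information accounts for this absence of a step.

Going by these compounds, whether another group at this place, such as an amine, a carboxylic acid or an amide with a longer chain, would move the number beyond the scatter remains open. On these data alone, compound 2 differs from compound 1 and from compound 3 in more than one place, so it also remains open which of those differences goes with its lower number, and whether the fluoro replacement would behave the same way with other groups elsewhere on the core.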